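A few compounds are considered here, and "the series" means these few. Any claim that something is new, unique, unknown or untested is made for them only; others in the source may bear on it.

The measured compounds in a functional assay on isolated protein for inhibition of Glucose-dependent insulinotropic receptor (Rattus norvegicus), read by HTRF and cAMP accumulation; on this read-out lower numbers stand for an effect already at smaller amounts and higher numbers for an effect only at larger amounts of compound:
compound 1 `Cc1nc(S(C)(=O)=O)ccc1Oc1ncnc(OC2CCN(C(=O)OC(C)C)CC2)c1F` gives 142 nM;
compound 2 `Cc1nc(S(C)(=O)=O)ccc1Oc1ncnc(OC2CCN(C(=O)O[C@H](C)CF)CC2)c1F` gives 1520 nM;
compound 3 `Cc1nc(S(C)(=O)=O)ccc1Oc1ncnc(OC2CCN(C(=O)O[C@H](C)C(F)(F)F)CC2)c1F` gives 110 nM.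

Compound 3 sits together with compound 1, as a 1.3-fold lower number from compound 1 to compound 3 (0.11 log units; within the scatter) shows, while compound 2 lies apart from both, seen in a 14-fold lower number from compound 2 to compound 3 (1.14 log units; beyond the scatter) and an 11-fold higher number from compound 1 to compound 2 (1.03 log units; beyond the scatter). Compound 4 `Cc1nc(S(C)(=O)=O)ccc1Oc1ncnc(OC2CCN(C(=O)OC3(C(F)(F)F)COC3)CC2)c1F` differs from compound 3 by 3-(trifluoromethyl)oxetan-3-yl in place of 1-(trifluoromethyl)ethyl on an oxygen next to a carbonyl group. Within the data shown here, the trifluoromethyl that separates compound 2 from compound 3 is kept, so the large step there does not bear on this change; no measured step tests closing the chain into an oxetane. The step from compound 3 to compound 4 in this assay is therefore expected to be modest, a 1.8-fold higher number from compound 3 to compound 4 (0.26 log units; within the scatter), with a wide range. Compound 4 is estimated at 200 nM, between 60 nM and 700 nM.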

Compound 4, half-maximal effective concentration: 342 nM
Compound 4: the middle estimate sits 1.7-fold (0.23 log units) below what was measured; measured number inside the range.
By their numbers in this assay, from the lowest: compounds 3 and 1 (each within the scatter of the next); then compound 4; then compound 2.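

In this assay, closing the chain into 3-(trifluoromethyl)oxetan-3-yl has a cost beyond the scatter (a 3.1-fold higher number from compound 3 to compound 4 (0.49 log units; beyond the scatter)), whereas replacing isopropyl with 1-(trifluoromethyl)ethyl had stayed within it. The oxetane also falls short of isopropyl (a 2.4-fold higher number from compound 1 to compound 4 (0.38 log units; beyond the scatter)) but improves on 1-(fluoromethyl)ethyl (a 4.4-fold lower number from compound 2 to compound 4 (0.65 log units; beyond the scatter)), so this position accepts the ring without gaining from it. Nothing available accounts for these steps. On these data alone, it remains open whether an unsubstituted oxetan-3-yl, a longer chain or an amine on an oxygen next to a carbonyl group would match compound 3.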